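The compounds below may be only part of what the source reports. "The series", "measured", "known", "first", "only" and "open" are said of these compounds alone.

Compound 1 `CC(C)OC(=O)N1CCC(Oc2ncnc3c2CCN3c2ccc(S(C)(=O)=O)cc2F)CC1` gives 91% in a functional assay on CHO-K1 cells with Glucose-dependent insulinotropic receptor (Homo sapiens) as the target, read by a luciferase reporter, with a stated time of 5 h; a higher number here means a larger maximal response, a lower number a smaller maximal response.
Compound 2 `CCCCOC(=O)N1CCC(Oc2ncnc3c2CCN3c2ccc(S(C)(=O)=O)cc2F)CC1` gives 131% in this assay.

For the measured compounds named here, of the two measured compounds, compound 2 stands highest in this assay; the only other compound, compound 1, sits at a distance described by the single measured step, a number 40 percentage points higher from compound 1 to compound 2 (beyond the scatter), which lies beyond the scatter.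

Compound 3 `CSC(=O)N1CCC(Oc2ncnc3c2CCN3c2ccc(S(C)(=O)=O)cc2F)CC1` has not yet been measured. It differs from compound 2 by methylsulfanyl in place of butoxy on a carbonyl carbon. Going by the values given here, the one measured step that bears on this change is a number 40 percentage points higher from compound 1 to compound 2 (beyond the scatter): there the group on an oxygen next to a carbonyl group was lengthened and the maximal response rose by a large amount. In compound 3 the butoxy is removed altogether and a group of two heavy atoms enters on the carbonyl carbon, so compound 3 carries a shorter group than compound 1 did. Since the shorter of the two measured groups gave the lower number, one expects a step downward in this assay, of about a number 36 percentage points lower from compound 2 to compound 3 (beyond the scatter). Compound 3 is therefore estimated at 95%, with a range from 70% to 125%.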

Compound 3, largest response reached (reported as percent of maximum), in percent of the reference or control that the assay uses: 135%
The estimate for compound 3 lay 40 percentage points below the measured number; the measured number lies above the stated range.
By their numbers in this assay, from the lowest: compound 1; then compounds 2 and 3 (each within the scatter of the next).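

On this carbonyl carbon, which also carries the amide-type nitrogen in a ring, the response in this assay does not fall with a smaller group: methylsulfanyl, with 2 heavy atoms, replaces butoxy, with 5, and the result is a number 4 percentage points higher from compound 2 to compound 3 (within the scatter). The earlier pair had suggested that a small group would go with the lower number, but compound 3 goes against that reading, with a number 44 percentage points higher from compound 1 to compound 3 (beyond the scatter), so group size alone does not order these three compounds, and an oxygen attached to the carbonyl carbon is not required for the high maximal response. No measurement given here explains why methylsulfanyl matches butoxy and exceeds isopropoxy in this way.

For the compounds shown here, the three compounds cannot separate the effect of the sulfur from that of the shape of the chain, since no pair shows the same chain on oxygen and on sulfur, so methoxy and butylsulfanyl would be the direct tests. From the compounds shown here alone, it also remains open whether an amine on the carbonyl carbon would keep the maximal response in this assay.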